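Replacing the aryl group on the enone chain of compound 3

A few compounds are considered here, and "the series" means these few. Any claim that something is new, unique, unknown or untested is made for them only; others in the source may bear on it.

Compound 1, `Cc1ccc(CS(=O)(=O)/C(=C/c2c[nH]c3ccc(Br)cc23)C(=O)c2ccc(Cl)cc2)cc1`, gives 10000 nM in a functional assay on DU-145 cells (Homo sapiens) for inhibition, read by trypan blue exclusion, with a stated time of 96 h; a lower number here means a stronger inhibitor of growth, a higher number a weaker inhibitor of growth.
Compound 2, `COc1ccccc1/C=C(\C(=O)c1ccc(Cl)cc1)S(=O)(=O)Cc1ccc(Cl)c(Cl)c1`, gives 1000 nM.
Compound 3, `Cc1ccc(CS(=O)(=O)/C(=C/c2cc(C)cc(C)c2)C(=O)c2ccc(Cl)cc2)cc1`, gives 10000 nM.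

Compound 3 stands level with compound 1 at the high end of the three numbers, within the scatter of it, and compound 2 gives a number far below both. Among the measured compounds shown here, the one step measured on this chain, no change at the digits printed from compound 1 to compound 3 (within the scatter), shows no change. Compound 4, `COc1ccccc1/C=C(\C(=O)c1ccc(Cl)cc1)S(=O)(=O)Cc1ccc(C)cc1`, differs from compound 3 as follows: 2-methoxyphenyl in place of 3,5-dimethylphenyl on a double-bonded chain carbon bound to a double-bonded chain carbon. For the measured compounds named here, no measured step shows this exact exchange, but compound 2 carries the same 2-methoxyphenyl group with a different benzyl sulfone and gives 1000 nM. A lower number for compound 4 is therefore expected, a 3.3-fold lower number from compound 3 to compound 4 (0.52 log units; beyond the scatter), with wide uncertainty. Compound 4 is estimated at 3000 nM, ranging from 1000 nM to 10000 nM.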

Compound 4, concentration for 50% growth inhibition: 10000 nM
Estimate against measurement, compound 4: 3.3-fold (0.52 log units) below, within the range that was stated.
By their numbers in this assay, from the lowest: compound 2; then compounds 1, 3 and 4 (each within the scatter of the next).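

In this assay the 2-methoxyphenyl group on the double-bonded chain carbon does not by itself give a lower number (no change at the digits printed from compound 3 to compound 4 (within the scatter)) and (no change at the digits printed from compound 1 to compound 4 (within the scatter)). The exchange on the saturated chain carbon bound to a sulfonyl sulfur does separate two compounds, with 4-methylphenyl in place of 3,4-dichlorophenyl (a 10-fold higher number from compound 2 to compound 4 (1.00 log units; beyond the scatter)). The lower number of compound 2 therefore goes with its 3,4-dichlorophenyl group in this pair. No measurement given here explains this difference. On these data alone, it remains open whether 3,4-dichlorophenyl gives a lower number alongside 3,5-dimethylphenyl or 5-bromo-1H-indol-3-yl, and how an amine or a carboxylic acid on the aryl group would read.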